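A few compounds are considered here, and "the series" means these few. Any claim that something is new, unique, unknown or untested is made for them only; others in the source may bear on it.

Compound 1, `COc1ccc(S(=O)(=O)c2cnc3ccc(C)cc3c2N2CCC(C)CC2)cc1`: 62%
Compound 2, `COc1ccc(S(=O)(=O)c2cnc3ccc(C)cc3c2N2CCC(C)CC2)cc1Cl`: 93%
Compound 3, `Cc1ccc2ncc(S(=O)(=O)c3cc(F)cc(F)c3)c(N3CCC(C)CC3)c2c1`: 72%

These three compounds share one core and were measured in an assay on isolated protein for displacement of a labelled ligand from metabotropic glutamate receptor 5 (Homo sapiens), with a stated time of 60 min, tested at 1 uM; a lower number here means less inhibition, a higher number more inhibition at the concentration tested (going by the name of the read-out). Compound 3 stands second highest of the three numbers. The nearest value is that of compound 1, and the step between them, a number 10 percentage points higher from compound 1 to compound 3 (within the scatter), is within the scatter, so no order can be read between those two. The furthest value is that of compound 2, and the step of a number 21 percentage points lower from compound 2 to compound 3 (beyond the scatter) lies beyond the scatter. The largest step in the set is a number 31 percentage points higher from compound 1 to compound 2 (beyond the scatter), a change of chloro in place of hydrogen on an aromatic carbon.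

Compound 4 is `Cc1ccc(S(=O)(=O)c2cnc3ccc(C)cc3c2N2CCC(C)CC2)cc1`. It differs from compound 3 by 4-methylphenyl in place of 3,5-difluorophenyl on a sulfonyl sulfur. Among the measured compounds shown here, the steps that bear on this change are the two that swap the group on the sulfonyl sulfur: a number 10 percentage points higher from compound 1 to compound 3 (within the scatter) was within the scatter, and a number 21 percentage points lower from compound 2 to compound 3 (beyond the scatter) was modest. For the measured compounds named here, none of the measured compounds carries 4-methylphenyl, so the closest guide is the group 4-methoxyphenyl in compound 1, whose value sits within the scatter of compound 3. No step beyond the scatter is expected in this assay. Compound 4 is therefore estimated at 68%, with a range from 45% to 88%. That estimate means an expected step of a number 4 percentage points lower from compound 3 to compound 4 (within the scatter), within the scatter.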

Compound 4, a percentage reported as inhibition, at one concentration (the size of the read-out at that concentration, not a potency): 82%
Compound 4: middle estimate off by 14 percentage points, on the low side, within the range that was stated.
By their numbers in this assay, from the lowest: compounds 1, 3 and 4 (each within the scatter of the next, the first and the last beyond it); then compound 2.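

In this assay, among the compounds shown here, the step of a number 20 percentage points higher from compound 1 to compound 4 (beyond the scatter) shows for the first time that a change of one small group on the aryl ring attached to the sulfonyl sulfur, with no chloro involved, can move the number beyond the scatter. The step of a number 10 percentage points higher from compound 3 to compound 4 (within the scatter) stays inside that scatter, so no order can be read between 4-methylphenyl and 3,5-difluorophenyl on the sulfonyl sulfur, even though these two groups have no substituent in common. The step of a number 11 percentage points lower from compound 2 to compound 4 (beyond the scatter) shows that 4-methylphenyl does not close the gap to 3-chloro-4-methoxyphenyl, and compound 2 remains beyond the scatter of every other compound as the highest of the four.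

Nothing given here accounts for any of these steps. Open questions are whether chloro in place of hydrogen on an aromatic carbon would raise the number from compound 4 as it does from compound 1, and how a trifluoromethyl, a nitrile or an ethyl in place of the methyl of 4-methylphenyl would read in this assay at this position.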